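An Iodo Group Takes the Place of an Ethoxy Chain

The source may hold more compounds than are shown below. What is called first, only, known or untested is meant among the compounds shown, and "the series" means these compounds.

Compound 1 `CCOc1ccccc1Cc1cnc(N)nc1N` is, in an assay for inhibition of Dihydrofolate reductase (Gallus gallus) (on this read-out higher numbers stand for weaker inhibition and lower numbers for stronger inhibition), the weaker of the two measured compounds: compound 1 gives 24500 nM, the highest number shown. Going by the values given here, its nearest neighbour, compound 2 `Nc1ncc(Cc2ccccc2OCc2ccccc2)c(N)n1`, gives 9120 nM in this assay, and the single measured step, a 2.7-fold lower number from compound 1 to compound 2 (0.43 log units; beyond the scatter), comes from a phenyl in place of methyl on a saturated chain carbon bound to an oxygen on an aromatic ring. Compound 3 `Nc1ncc(Cc2ccccc2I)c(N)n1` differs from compound 1 in another way: iodo in place of ethoxy on an aromatic carbon. Among the compounds with values here, no measured step removes the ethoxy group itself, so the only guide is that one change to this group in compound 1 moved the number by a modest amount. For compound 3 a step of a 1.6-fold lower number from compound 1 to compound 3 (0.21 log units; within the scatter) is therefore expected, small and uncertain in direction. Compound 3 is estimated at 15000 nM, with a likely range from 3000 nM to 60000 nM.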

Compound 3, inhibition constant: 8710 nM
For compound 3 the middle estimate is 1.7-fold (0.24 log units) above the measured one; low and high end bracket the measured number.
By their numbers in this assay, from the lowest: compounds 3 and 2 (each within the scatter of the next); then compound 1.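

In this assay, iodo in place of ethoxy on this aromatic carbon gives a 2.8-fold lower number from compound 1 to compound 3 (0.45 log units; beyond the scatter) and so shows that a chain joined through oxygen is not needed at this position for a lower number. The swap replaces the 3 heavy atoms of ethoxy, including its hydrogen-bond acceptor, with a single iodine atom. Compound 3 nevertheless stands within the scatter of compound 2, which keeps the oxygen and carries a phenyl on its chain, so two very different groups at this place give matching numbers, and the data offer no explanation for the change from compound 1.

Iodo is the only halogen among these compounds, so it remains open whether chloro or bromo on the same carbon would give a similar number. An amine or a carboxylic acid at this place could also show how much the number depends on the kind of group there.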